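The source may report more compounds than this note shows. Statements on the series, on what has been measured and on what is new or still open speak of the compounds shown alone.

Compound 1 `CCc1cc(N)ccc1-c1nc2ccccc2s1`: in a functional assay on MCF7 cells (Homo sapiens) for inhibition (a higher number here means a weaker inhibitor, a lower number a stronger inhibitor), compound 1 gives < 0.1 nM, a limit of the assay and not a number.
Compound 2 `N#Cc1cc(N)ccc1-c1nc2ccccc2s1`: in this assay compound 2 gives < 10 nM, likewise a limit and not a number.

Within the data shown here, compound 2 therefore stands only at a limit in this assay, and the one further value shown, that of compound 1, is a limit too. The step from compound 1 to compound 2 is a step that the two limits leave unreadable from compound 1 to compound 2, because both values sit at limits, namely the limit of < 0.1 nM in this assay, at which 1 of the 2 values shown sits, and (the limit of < 10 nM in this assay, at which 1 of the 2 values shown sits). The change of an ethyl group to a cyano group on that aromatic carbon thus gives no readable size.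

Compound 3 `Nc1ccc(-c2nc3ccccc3s2)c(O)c1` differs from compound 2 by hydroxy in place of cyano on an aromatic carbon. Among the measured compounds shown here, only the unreadable step from compound 1 to compound 2 bears on this change, so no measured step sets its size. Compound 3 is therefore expected to lie near where compound 2 is placed, and the step that the limit leaves unreadable from compound 2 to compound 3 is estimated as none beyond the scatter. For compound 3 in this assay the estimate is 5 nM, with a range from 0.5 nM to 50 nM.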

Compound 3, half-maximal inhibitory concentration: > 0.1 nM
Compound 3: only a limit was reported; the forecaster's own chance of this, stated with the estimate: 35%; the middle value lies beyond the limit too.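

Compound 3 adds a third group at this aromatic carbon, ortho to a group of 9 heavy atoms and meta to an amino group, but its value is a limit and not a number: the limit of > 0.1 nM in this assay, at which 1 of the 3 values shown sits. The one thing this shows is a direction for the change of ethyl to hydroxy in this assay, which gives a number no lower from compound 1 to compound 3 (the limit leaves the size open). Compound 3 is thus no stronger an inhibitor than compound 1, while the step for hydroxy in place of cyano and the step for cyano in place of ethyl cannot be read, so the three groups cannot be ranked by size of effect.

The compounds shown leave open how far hydroxy actually lies from ethyl or from cyano at this carbon, since no exact value is available for any of the three. As far as these compounds go, it also remains open where a methoxy group, a fluorine atom or a longer chain at the same carbon would fall relative to ethyl and hydroxy.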